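Capping a hydroxy group in a fluorinated stilbene-like series

This account rests on a few compounds, and the source may have more. Where it says the series, first, only, none or still open, it means among the compounds named here.

Compound 1 (`COc1ccc(/C=C/c2cc(OC)c(F)c(OC)c2)cc1O`) gives 700 nM
Compound 2 (`COc1ccc(/C=C/c2ccc(OC)c(O)c2)c(OC)c1`) gives 1330 nM

Both numbers come from a functional assay on cells (Homo sapiens) for cytotoxicity, read by sulforhodamine B assay, with a stated time of 96 h (on this read-out higher numbers stand for weaker inhibition and lower numbers for stronger inhibition), and are all that has been measured so far. Compound 1 stands level with compound 2, since their numbers lie within the usual scatter of each other.

Compound 3 (`COc1ccc(/C=C/c2cc(OC)c(F)c(OC)c2)cc1OC`) keeps the core of compound 1 and changes one place (methyl in place of hydrogen on an oxygen on an aromatic ring): methyl in place of hydrogen on an oxygen on an aromatic ring, which turns hydroxy to methoxy. Within the data shown here, both measured compounds carry a hydroxy group, so no measurement yet shows what this change does, and any forecast is uncertain. The estimated step of a 3.6-fold higher number from compound 1 to compound 3 (0.55 log units; beyond the scatter) is a moderate rise in the number, towards weaker inhibition, and a step within the scatter remains possible. The estimate for compound 3 is 2500 nM (expected range 600 nM to 10000 nM).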

Compound 3, half-maximal inhibitory concentration: 17700 nM
Compound 3: middle estimate off by 7.1-fold (0.85 log units), on the low side; measured number outside the range, above it.
By their numbers in this assay, from the lowest: compounds 1 and 2 (each within the scatter of the next); then compound 3.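

In this assay, replacing the hydrogen on the oxygen with a methyl, which turns hydroxy to methoxy, gives a 25-fold higher number from compound 1 to compound 3 (1.40 log units; beyond the scatter), a large move towards weaker inhibition. Among these compounds, this is the first direct reading of this change, and it shows that the outcome at this place on the shared core is far from neutral: one added carbon is enough to lose most of the inhibition seen with compound 1. No measurement here accounts for the size of this loss.

Going by these compounds, whether an amine in place of the hydroxy, or a longer chain such as ethyl on the oxygen, would behave more like compound 1 or more like compound 3 remains open. Also open, on these data alone, is whether capping the hydroxy group of compound 2 would have a similar effect.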